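Carbonyl substituent step from compound 1 to compound 4

The source may hold more compounds than are shown below. What is called first, only, known or untested is meant among the compounds shown, and "the series" means these compounds.

compound 1 `COc1ncc(-c2ccc3nc(NC(=O)N4CCCC4)nn3c2)cc1NS(=O)(=O)c1ccc(F)cc1`: 3570 nM
compound 2 `COc1ncc(-c2ccc3nc(NC(=O)NCCN4CCCC4)nn3c2)cc1NS(=O)(=O)c1ccc(F)cc1`: 960 nM
compound 3 `COc1ncc(-c2ccc3nc(NC(=O)NC4CC4)nn3c2)cc1NS(=O)(=O)c1ccc(F)cc1`: 210 nM
compound 4 `COc1ncc(-c2ccc3nc(NC(=O)NCCN4CCCCC4)nn3c2)cc1NS(=O)(=O)c1ccc(F)cc1`: not yet measured

In a functional assay on A549 cells (Homo sapiens) for cytotoxicity, read by MTT assay, with a stated time of 72 h (a lower number here means a stronger inhibitor, a higher number a weaker inhibitor), compound 1 has the highest of the three numbers at 3570 nM and is the starting point here. The change to compound 4 is (2-(piperidin-1-yl)ethyl)amino in place of pyrrolidin-1-yl on a carbonyl carbon in this one place.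

Two measured steps replace the same pyrrolidin-1-yl on a carbonyl carbon. The closer precedent, with (2-(pyrrolidin-1-yl)ethyl)amino entering, is a 3.7-fold lower number from compound 1 to compound 2 (0.57 log units; beyond the scatter) and counts as modest. With cyclopropylamino entering, the result is a 17-fold lower number from compound 1 to compound 3 (1.23 log units; beyond the scatter) and counts as large. Among the measured compounds shown here, both run in the same direction, though only two steps support this. The remaining comparison, a 4.6-fold lower number from compound 2 to compound 3 (0.66 log units; beyond the scatter), shows that the size depends on the entering group. No measurement compares piperidin-1-yl and pyrrolidin-1-yl ends on this chain.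

A modest drop is expected, resting on the precedent of compound 2 with a 3.7-fold lower number from compound 1 to compound 2 (0.57 log units; beyond the scatter) as its step. The expected step in this assay is a 4.0-fold lower number from compound 1 to compound 4 (0.60 log units; beyond the scatter) as estimated here. Compound 4 is estimated at 900 nM with an expected range of 350 nM to 2300 nM in this estimate.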

Compound 4, half-maximal inhibitory concentration: 610 nM
For compound 4 the middle estimate is 1.5-fold (0.17 log units) above the measured one; the measured number falls inside the stated range.
By their numbers in this assay, from the lowest: compound 3; then compounds 4 and 2 (each within the scatter of the next); then compound 1.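

In this assay, exchanging the ring at the chain end leaves the number within the scatter (a 1.6-fold lower number from compound 2 to compound 4 (0.20 log units; within the scatter)), so piperidin-1-yl and pyrrolidin-1-yl cannot be told apart on this chain. The (2-(piperidin-1-yl)ethyl)amino group on the carbonyl carbon also gives a lower number than pyrrolidin-1-yl (a 5.9-fold lower number from compound 1 to compound 4 (0.77 log units; beyond the scatter)), making all three replacements shown run the same way, while the chain on the amide-type nitrogen still does not match cyclopropyl (a 2.9-fold higher number from compound 3 to compound 4 (0.46 log units; beyond the scatter)). No evidence on the cause of these steps is available.

Open, going by these compounds, is whether a morpholine ring at the chain end would also stay within the scatter of these two amines. Also open, on these data alone, is how a propyl chain in place of the ethyl chain carrying piperidin-1-yl would change the number.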